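Bromophenyl Replaces Dimethylphenyl on the Sulfonamide Nitrogen

The source may hold more compounds than are shown below. What is called first, only, known or untested is meant among the compounds shown, and "the series" means these compounds.

Of the compounds shown here, two built on the shared core have been measured. Going by the values given here, compound 1 `Cc1ccc(NS(=O)(=O)c2ccc(N3CCNC3=O)cc2)cc1C` is the stronger of the two in a functional assay on MCF7 cells (Homo sapiens) for antiproliferative activity, read by sulforhodamine B assay, with a stated time of 48 h (a lower number here means a stronger inhibitor, a higher number a weaker inhibitor), where compound 1 gives 230 nM, the lowest number so far. Compound 2 `O=C1NCCN1c1ccc(S(=O)(=O)Nc2ccc(OC(F)F)cc2)cc1` gives 760 nM in this assay, a gap beyond the usual scatter. Compound 3 `O=C1NCCN1c1ccc(S(=O)(=O)Nc2ccc(Br)cc2)cc1` awaits measurement. It differs from compound 1 in a single place: 4-bromophenyl in place of 3,4-dimethylphenyl on a sulfonamide nitrogen. Among the compounds with values here, no pair of measured compounds shows this exact change, so the size of the step has to be judged from compound 1 and compound 2 alone. The step of a 1.7-fold higher number from compound 1 to compound 3 (0.24 log units; within the scatter) is expected to be small, either within the scatter or leaning toward a weaker inhibitor. For compound 3 the estimate in this assay is 400 nM, with a range from 150 nM to 1200 nM.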

Compound 3, half-maximal inhibitory concentration: 240 nM
Estimate against measurement, compound 3: 1.7-fold (0.22 log units) above; low and high end bracket the measured number.
By their numbers in this assay, from the lowest: compounds 1 and 3 (each within the scatter of the next); then compound 2.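

In this assay, 4-bromophenyl in place of 3,4-dimethylphenyl on the sulfonamide nitrogen gives a 1.0-fold higher number from compound 1 to compound 3 (0.02 log units; within the scatter) with no shift beyond the scatter, so this position accepts either aromatic group with the number unchanged. Bromo in place of difluoromethoxy on an aromatic carbon now gives a direct reading, a 3.2-fold lower number from compound 2 to compound 3 (0.50 log units; beyond the scatter) beyond the scatter, which shows that the group at this place on the ring can move the number. Nothing shown here gives a measured reason for either step.

From the compounds shown here alone, whether an amine or a carboxylic acid on that aromatic carbon would keep the number of compound 3 or move it remains open. Going by these compounds, whether these two steps carry over to other cell lines also remains open.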